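Methyl in place of trifluoromethyl: a repeated change

The compounds below may be only part of what the source reports. "The series", "measured", "known", "first", "only" and "open" are said of these compounds alone.

Measured so far in a functional assay on HeLa cells (Homo sapiens) for antiproliferative activity, with a stated time of 24 h; on this read-out lower numbers stand for stronger inhibition and higher numbers for weaker inhibition:
- compound 1, `NC(=O)c1c(NC(=O)c2ccccc2Cl)sc2c1CCN(C(=S)Nc1ccccc1C(F)(F)F)C2`, gives 26700 nM
- compound 2, `Cc1ccccc1NC(=S)N1CCc2c(sc(NC(=O)c3ccccc3Cl)c2C(N)=O)C1`, gives > 50000 nM, which is a limit of the assay and not a number
- compound 3, `NC(=O)c1c(NC(=O)c2ccccc2C(F)(F)F)sc2c1CCN(C(=S)Nc1ccccc1Cl)C2`, gives 46900 nM

The step of an at least 1.8-fold higher number from compound 1 to compound 2 (0.27 log units; that floor lies within the scatter) is the change (methyl in place of trifluoromethyl on an aromatic carbon). Its size is known only as a floor, because the value for compound 2 is the limit of > 50000 nM in this assay, at which 1 of the 3 values shown sits. Compound 3 has the same atoms as compound 1 joined differently; the difference between the two cores is not broken down here. In this assay compound 3 and compound 1 sit within the scatter of each other, so no order between them is claimed.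

Compound 4, `Cc1ccccc1C(=O)Nc1sc2c(c1C(N)=O)CCN(C(=S)Nc1ccccc1Cl)C2`, is not yet measured. Among the compounds with values here, it differs from compound 3 by methyl in place of trifluoromethyl on an aromatic carbon, and this is the same change as the one from compound 1 to compound 2, in the same place. Within the data shown here, the only guide is that first step, where the number rose at least as far as the limit. Compound 3 already starts high with 46900 nM. For compound 4 the step of a 1.8-fold higher number from compound 3 to compound 4 (0.26 log units; within the scatter) is therefore expected, read as an estimate and not a measurement. For compound 4 the expected value is 85000 nM, with a range from 35000 nM to 200000 nM, and a real chance that the assay again returns only a limit.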

Compound 4, half-maximal inhibitory concentration: 35300 nM
Compound 4: middle estimate off by 2.4-fold (0.38 log units), on the high side; measured number inside the range.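

In this assay, the change from 2-(trifluoromethyl)phenyl to 2-methylphenyl on the core of compound 3 gives a 1.3-fold lower number from compound 3 to compound 4 (0.12 log units; within the scatter), so on this core the change has no effect that can be told from the usual variation between repeats. Set beside the earlier case, the two readings compare as follows: the same change on two cores in this assay, an at least 1.8-fold higher number (0.27 log units; that floor lies within the scatter) from compound 1 to compound 2 and a 1.3-fold lower number (0.12 log units; within the scatter) from compound 3 to compound 4; the limit leaves it open whether they differ. The floor of the first step and the whole of the second lie within the scatter, so the series does not show that carrying this change between the two cores raises or lowers the number, nor does it show the change to be neutral on the core of compound 1, where the value of compound 2 is only a limit: the limit of > 50000 nM in this assay, at which 1 of the 4 values shown sits.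

The compounds shown leave open how the number responds when the aromatic carbon carrying methyl or trifluoromethyl bears another group instead, such as an amine, a carboxylic acid or a longer chain. They also leave open what a nitrile in place of the chlorine would do on either core, and whether any such change would give a number clearly apart from those of compound 3 and compound 4.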